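This account rests on a few compounds, and the source may have more. Where it says the series, first, only, none or still open, it means among the compounds named here.

Measured so far in an assay on HEK293 cells for displacement of a labelled ligand from NPC1-like intracellular cholesterol transporter 1 (Homo sapiens); on this read-out lower numbers stand for stronger inhibition and higher numbers for weaker inhibition: compound 1 `CC(C)(C)c1ccc(C(=O)N2CCC3(CC2)C(=O)N(CC(=O)NCCO)CN3c2ccccc2)cc1` gives 1000 nM; compound 2 `CCOC(=O)C1CCN(C(=O)CN2CN(c3ccccc3)C3(CCN(C(=O)c4ccc(C(C)(C)C)cc4)CC3)C2=O)CC1` gives 3100 nM.

Among the measured compounds shown here, compound 2 holds the higher of the two numbers, with a 3.1-fold higher number from compound 1 to compound 2 (0.49 log units; beyond the scatter) being its only neighbour. Compound 3 `CC(C)(C)OC(=O)NC1CCN(C(=O)CN2CN(c3ccccc3)C3(CCN(C(=O)c4ccc(C(C)(C)C)cc4)CC3)C2=O)CC1` differs from compound 2 by (tert-butoxycarbonyl)amino in place of ethoxycarbonyl on a saturated ring carbon. For the measured compounds named here, the one measured step, a 3.1-fold higher number from compound 1 to compound 2 (0.49 log units; beyond the scatter), exchanges the whole group on the carbonyl carbon and so does not test a change on the saturated ring carbon; it offers no direction. In this assay compound 3 is therefore expected near 2500 nM, within 800 nM to 8000 nM. The expected step is a 1.2-fold lower number from compound 2 to compound 3 (0.09 log units; within the scatter), within the scatter.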

Compound 3, half-maximal inhibitory concentration: 8300 nM
Compound 3: the middle estimate sits 3.3-fold (0.52 log units) below what was measured; measured number outside the range, above it.
By their numbers in this assay, from the lowest: compound 1; then compound 2; then compound 3.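

At the saturated ring carbon three ring bonds from the ring nitrogen, this assay records a 2.7-fold higher number from compound 2 to compound 3 (0.43 log units; beyond the scatter) when (tert-butoxycarbonyl)amino replaces ethoxycarbonyl. This is the first change shown at this position, and it shows that the read-out responds to the group carried there, with the entering carbamate-bearing group on the weaker side. No data given here bear on the reason for this step. Going by these compounds, whether an amine or a carboxylic acid on this ring carbon would give a lower number stays open. Also open, on these data alone, is which part of the exchange carries the step, as the nitrogen, its hydrogen-bond donor and the tert-butyl group enter together.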